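Benzyl substitution on the tertiary amine side chain

The source may hold more compounds than are shown below. What is called first, only, known or untested is meant among the compounds shown, and "the series" means these compounds.

Measured compounds:
compound 1 `COc1cc2sn(CCCN(C)Cc3ccccc3)c(=O)c2cc1OC` — 6900 nM
compound 2 `CCN(CCCn1sc2cc(OC)c(OC)cc2c1=O)Cc1ccccc1` — 9900 nM
compound 3 `CCN(CCCn1sc2cc(OC)c(OC)cc2c1=O)Cc1ccccc1OC` — 15500 nM

All numbers come from an assay on isolated protein for inhibition of Amine oxidase [flavin-containing] A (Homo sapiens), read by fluorescence, with a stated time of 30 min; on this read-out lower numbers stand for stronger inhibition and higher numbers for weaker inhibition. Compound 2 stands second highest of the three, with compound 1 its nearest neighbour and compound 3 its furthest; both steps, a 1.4-fold higher number from compound 1 to compound 2 (0.16 log units; within the scatter) and a 1.6-fold higher number from compound 2 to compound 3 (0.19 log units; within the scatter), lie within the scatter. Compound 4 `CCN(CCCn1sc2cc(OC)c(OC)cc2c1=O)Cc1ccccc1N(C)C` differs from compound 2 by dimethylamino in place of hydrogen on an aromatic carbon. The step that bears on this is the one at the same aromatic carbon, a 1.6-fold higher number from compound 2 to compound 3 (0.19 log units; within the scatter), which stayed within the scatter; the change at the amine, a 1.4-fold higher number from compound 1 to compound 2 (0.16 log units; within the scatter), did as well. For compound 4 no step beyond the scatter is therefore expected in this assay, if anything a somewhat higher number. Compound 4 is estimated at 13000 nM, range 5000 nM to 35000 nM, an expected 1.3-fold higher number from compound 2 to compound 4 (0.12 log units; within the scatter).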

Compound 4, half-maximal inhibitory concentration: 16600 nM
Compound 4: middle estimate off by 1.3-fold (0.11 log units), on the low side; the measured number falls inside the stated range.
By their numbers in this assay, from the lowest: compounds 1, 2, 3 and 4 (each within the scatter of the next, the first and the last beyond it).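

In this assay, the aromatic carbon ortho to a large group also takes dimethylamino in place of hydrogen, with a 1.7-fold higher number from compound 2 to compound 4 (0.22 log units; within the scatter) inside the scatter. Dimethylamino in place of methoxy at that carbon gives a 1.1-fold higher number from compound 3 to compound 4 (0.03 log units; within the scatter) and likewise stays within the scatter, so these two compounds do not separate the two groups. Nothing available explains this result. Going by these compounds, whether a carboxylic acid or a trifluoromethyl at this aromatic carbon would also stay within the scatter remains open. So does the outcome of a longer chain on the amine nitrogen.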